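Aryl-sulfamide series: butyl on the aromatic ring, second case

The compounds below may be only part of what the source reports. "The series", "measured", "known", "first", "only" and "open" are said of these compounds alone.

Measured so far:
compound 1 `NS(=O)(=O)NCC1CCN(c2cc(-c3ccccc3)ncn2)CC1` — 34300 nM
compound 2 `CCCCc1ccc(-c2cc(N3CCC(CNS(N)(=O)=O)CC3)ncn2)cc1` — 21800 nM
compound 3 `NS(=O)(=O)NCCC1CCN(c2cc(-c3ccccc3)ncn2)CC1` — 53200 nM

In a functional assay on MCF7 cells (Homo sapiens) for antiproliferative activity, read by sulforhodamine B assay, with a stated time of 48 h (a lower number here means a stronger inhibitor of growth, a higher number a weaker inhibitor of growth), compound 3 carries the highest of the three numbers; its gap to compound 1 is within the scatter, its gap to compound 2 beyond it. Compound 4 `CCCCc1ccc(-c2cc(N3CCC(CCNS(N)(=O)=O)CC3)ncn2)cc1` differs from compound 3 by butyl in place of hydrogen on an aromatic carbon. One measured step is of the same kind: a 1.6-fold lower number from compound 1 to compound 2 (0.20 log units; within the scatter), which stayed within the scatter. The same change on compound 3 is therefore expected to give a step of similar size and direction, a 1.6-fold lower number from compound 3 to compound 4 (0.21 log units; within the scatter), nothing clearly beyond the scatter. For compound 4 the estimate in this assay is 33000 nM, with a range from 15000 nM to 75000 nM.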

Compound 4, concentration for 50% growth inhibition: 11300 nM
Compound 4: middle estimate off by 2.9-fold (0.47 log units), on the high side; the measured number lies below the stated range.
By their numbers in this assay, from the lowest: compounds 4, 2, 1 and 3 (each within the scatter of the next, the first and the last beyond it).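

In this assay, butyl in place of hydrogen on an aromatic carbon does not give one constant step, and a 4.7-fold lower number from compound 3 to compound 4 (0.67 log units; beyond the scatter) is the only case of this change beyond the scatter: the same change on two cores in this assay, a 1.6-fold lower number (0.20 log units; within the scatter) from compound 1 to compound 2 and a 4.7-fold lower number (0.67 log units; beyond the scatter) from compound 3 to compound 4, 3.0-fold (0.48 log units) apart, beyond the scatter of two such steps The (sulfamoylamino)methyl change, within the scatter on each core taken alone, gives a 1.9-fold lower number from compound 2 to compound 4 (0.29 log units; within the scatter), and its two cases also fail to match: the same change on two cores in this assay, a 1.6-fold higher number (0.19 log units; within the scatter) from compound 1 to compound 3 and a 1.9-fold lower number (0.29 log units; within the scatter) from compound 2 to compound 4, 3.0-fold (0.48 log units) apart, beyond the scatter of two such steps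

Open, from the compounds shown here alone, is how a chain longer than butyl, or a carboxylic acid, at that aromatic carbon would behave on either core. These four compounds also cannot show whether the dependence on the core extends beyond them.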